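Three chain amides at the assay limit and a fluorophenyl analogue

A few compounds are considered here, and "the series" means these few. Any claim that something is new, unique, unknown or untested is made for them only; others in the source may bear on it.

compound 1 `O=C(CCCCCCCCc1ccccc1)N1CCCCC1`: > 100000 nM
compound 2 `Cc1ccc(CCCCCCCCC(=O)N2CCCCC2)cc1`: > 100000 nM
compound 3 `N#Cc1ccc(CCCCCCCCC(=O)N2CCCCC2)cc1`: > 100000 nM

All three measured compounds were tested in a functional assay on PANC-1 cells (Homo sapiens) for cytotoxicity, read by WST assay, with a stated time of 24 h; on this read-out lower numbers stand for stronger inhibition and higher numbers for weaker inhibition. Compound 1 gives > 100000 nM, which is a limit of the assay and not a number. Compound 2 likewise gives > 100000 nM, a limit. Compound 3 also gives > 100000 nM, a limit, so compound 3 stands at the same limit as the other two, and the limit of > 100000 nM in this assay, at which 3 of the 3 values shown sit, sums up the whole picture. The steps a step that the two limits leave unreadable from compound 1 to compound 2, a step that the two limits leave unreadable from compound 1 to compound 3 and a step that the two limits leave unreadable from compound 2 to compound 3 therefore carry no readable size.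

Compound 4 `O=C(CCCCCCCCc1ccccc1F)N1CCCCC1` differs from compound 3 by 2-fluorophenyl in place of 4-cyanophenyl on a saturated chain carbon, eight bonds along the chain from a carbonyl carbon. Among the measured compounds shown here, no measured step between readable numbers bears on this change, since every step among the measured compounds is hidden by the limit. Compound 4 is therefore expected to behave like compound 3, with an estimated step that the limit leaves unreadable from compound 3 to compound 4 in this assay, most likely again ending at the limit. The estimate for compound 4 is 150000 nM, with a range from 50000 nM to 500000 nM.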

Compound 4, half-maximal inhibitory concentration: 98900 nM
For compound 4 the middle estimate is 1.5-fold (0.18 log units) above the measured one; measured number inside the range.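

In this assay compound 4 gives 98900 nM, so 2-fluorophenyl on a saturated chain carbon, eight bonds along the chain from a carbonyl carbon, yields the first readable number among the compounds shown. From the compounds shown here alone, the steps are a number no higher from compound 3 to compound 4 (the limit leaves the size open), a number no higher from compound 2 to compound 4 (the limit leaves the size open) and a number no higher from compound 1 to compound 4 (the limit leaves the size open); none of them can be read in size, and so the gain from this change remains unknown. Most of the picture still rests on one limit: the limit of > 100000 nM in this assay, at which 3 of the 4 values shown sit.

The compounds shown leave open whether a longer chain would give a lower number than compound 4 does. They also leave open how an amine or a carboxylic acid in place of the 2-fluorophenyl would read in this assay.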